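Working notes: aryl exchange on the ring nitrogen

The source may report more compounds than this note shows. Statements on the series, on what has been measured and on what is new or still open speak of the compounds shown alone.

Compound 1 `COc1ccc(Br)cc1Nc1cc(NC(=O)Nc2c(Cl)cccc2Cl)ncn1` carries 5-bromo-2-methoxyphenyl on a nitrogen on an aromatic ring and 2,6-dichlorophenyl on an amide-type nitrogen. In a functional assay on PC-9 cells (Homo sapiens) for inhibition, read by MTT assay, with a stated time of 48 h, tested at 10 uM (on this read-out lower numbers stand for less inhibition and higher numbers for more inhibition at the one concentration tested (going by the name of the read-out)), compound 1 gives 69%. Compound 2 `COc1ccc(Nc2cc(NC(=O)Nc3c(Cl)cccc3Cl)ncn2)cc1C` differs from compound 1 by 4-methoxy-3-methylphenyl in place of 5-bromo-2-methoxyphenyl on a nitrogen on an aromatic ring; in this assay compound 2 gives 80.1%, a step of a number 11.1 percentage points higher from compound 1 to compound 2 (beyond the scatter). Compound 3 `COc1cc(NC(=O)Nc2cc(Nc3cc(Br)ccc3OC)ncn2)cc(OC)c1` has a different core, the difference being (3,5-dimethoxyphenyl in place of 2,6-dichlorophenyl on an amide-type nitrogen); in this assay compound 3 gives 82.5%, a step of a number 13.5 percentage points higher from compound 1 to compound 3 (beyond the scatter). Compound 3 and compound 2 lie within the scatter of each other.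

Compound 4 `COc1cc(NC(=O)Nc2cc(Nc3ccc(OC)c(C)c3)ncn2)cc(OC)c1` stands to compound 3 as compound 2 stands to compound 1: the change is 4-methoxy-3-methylphenyl in place of 5-bromo-2-methoxyphenyl on a nitrogen on an aromatic ring, the same change at a place described in the same words, seen once before among these compounds. That earlier instance gave a number 11.1 percentage points higher from compound 1 to compound 2 (beyond the scatter). A step of similar direction is expected here, but smaller, since compound 3 already stands at 82.5% with little room left for the number to go higher. The expected step from compound 3 to compound 4 is a number 8.5 percentage points higher from compound 3 to compound 4 (within the scatter). For compound 4 in this assay the estimate is 91%, expected between 82% and 98%.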

Compound 4, a percentage reported as inhibition, at one concentration (the size of the read-out at that concentration, not a potency): 62%
Estimate against measurement, compound 4: 29 percentage points above, and the stated range ends above it.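

In this assay, 4-methoxy-3-methylphenyl in place of 5-bromo-2-methoxyphenyl on a nitrogen on an aromatic ring gives a number 20.5 percentage points lower from compound 3 to compound 4 (beyond the scatter), so this change does not carry over from one core to the other: the same change on two cores in this assay, a number 11.1 percentage points higher (beyond the scatter) from compound 1 to compound 2 and a number 20.5 percentage points lower (beyond the scatter) from compound 3 to compound 4, 31.6 percentage points apart, beyond the scatter of two such steps

Read from the other place, 3,5-dimethoxyphenyl in place of 2,6-dichlorophenyl on an amide-type nitrogen gives a number 18.1 percentage points lower from compound 2 to compound 4 (beyond the scatter), again opposite in direction to the earlier step: the same change on two cores in this assay, a number 13.5 percentage points higher (beyond the scatter) from compound 1 to compound 3 and a number 18.1 percentage points lower (beyond the scatter) from compound 2 to compound 4, 31.6 percentage points apart, beyond the scatter of two such steps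

Both comparisons rest on the same four compounds, so they form one observation that the two changes do not add up here; it gives no general rule for the series and no explanation of the reversal.

Still open, on these data alone, is whether the reversal recurs with other groups on the amide-type nitrogen, such as a phenyl carrying a carboxylic acid or a dimethylamino chain. Also open, as far as these compounds go, is whether it would appear at other concentrations, as a percentage at one concentration is not a potency.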